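This account rests on a few compounds, and the source may have more. Where it says the series, first, only, none or still open, it means among the compounds named here.

Three compounds sharing one core were measured in an in vitro assay on Sf21 cells for inhibition of high affinity 3',5'-cyclic-AMP phosphodiesterase 7A (Homo sapiens); on this read-out lower numbers stand for stronger inhibition and higher numbers for weaker inhibition. Compound 1 `CNc1nc(NC2(C#N)CCCCC2)nc(N2CCCC2)n1` carries a pyrrolidin-1-yl group and in this assay reaches only a limit of the assay, > 5000 nM (the limit of > 5000 nM in this assay, at which 1 of the 3 values shown sits). Compound 2 `CNc1nc(NC2(C#N)CCCCC2)nc(OC)n1` carries methoxy at that place and gives 521 nM in this assay. Compound 3 `CNc1nc(NC2(C#N)CCCCC2)nc(SC)n1` carries methylsulfanyl there and gives 46 nM in this assay, the lowest of the two numbers reported; compound 2 stands nearest to it an 11-fold lower number from compound 2 to compound 3 (1.05 log units; beyond the scatter). The steps from the pyrrolidin-1-yl compound an at least 9.5-fold lower number from compound 1 to compound 2 (0.98 log units; beyond the scatter) and an at least 100-fold lower number from compound 1 to compound 3 (2.03 log units; beyond the scatter) show that the number in this assay depends strongly on which group sits at this aromatic carbon.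

Compound 4 `CNc1nc(C#N)nc(NC2(C#N)CCCCC2)n1` differs from compound 3 in one place: cyano in place of methylsulfanyl on an aromatic carbon. Within the data shown here, no measured step introduces cyano, so the three measured steps bear on it only by showing how sensitive this position is: each exchange there moved the number beyond the scatter. A step beyond the scatter in this assay is therefore expected here as well, and with compound 3 holding the lowest number, the expected direction is toward a higher number. Compound 4 is estimated to give 300 nM in this assay, within 60 nM to 1500 nM. This corresponds to an expected step of a 6.5-fold higher number from compound 3 to compound 4 (0.81 log units; beyond the scatter).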

Compound 4, half-maximal inhibitory concentration: > 1000 nM
Compound 4 gave a limit, no number; the forecaster's own chance of this, stated with the estimate: 10%; at least 3.3-fold (0.52 log units) between middle value and limit.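

In this assay compound 4 gives only a limit of the assay and not a number: the limit of > 1000 nM in this assay, at which 1 of the 4 values shown sits.

Cyano and methylsulfanyl have the same count of heavy atoms and of hydrogen-bond acceptors, yet this exchange gives an at least 21-fold higher number from compound 3 to compound 4 (1.33 log units; beyond the scatter), so these counts alone do not set the number at this aromatic carbon, and the low number of compound 3 is lost with a second small group as well as with the pyrrolidin-1-yl group. The comparison with methoxy is less firm: the exchange gives an at least 1.9-fold higher number from compound 2 to compound 4 (0.28 log units; that floor lies within the scatter), and as that floor lies within the scatter, no order can be stated for these two groups, while the step between the two compounds that rest on limits cannot be read.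

On these data alone, how far the number rises with cyano stays open, since the result gives only a limit. As far as these compounds go, it also stays open whether a longer chain on the sulfur, such as ethylsulfanyl, or a single chlorine atom at this aromatic carbon would keep the low number of compound 3 or move it further.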